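Furan-2-yl in place of phenyl: compound 3

The compounds below may be only part of what the source reports. "The series", "measured", "known", "first", "only" and "open" are said of these compounds alone.

- compound 1 `CCCc1nn(C)c(C(N)=O)c1NC(=O)/C=C/c1ccccc1`: 3440 nM
- compound 2 `CCCc1nn(C)c(C(N)=O)c1NC(=O)c1cc(OC)c(OC)cc1OC`: 29500 nM

In a functional assay on MGC-803 cells (Homo sapiens) for cytotoxicity, read by MTT assay, with a stated time of 48 h (a higher number here means a weaker inhibitor, a lower number a stronger inhibitor), compound 1 gives the lower of the two numbers, and the gap up to compound 2 lies beyond the usual scatter. Compound 3 `CCCc1nn(C)c(C(N)=O)c1NC(=O)/C=C/c1ccco1` has not yet been measured. It carries furan-2-yl in place of phenyl on a double-bonded chain carbon bound to a double-bonded chain carbon. For the measured compounds named here, no measured pair shows this change, so the expectation is cautious. The expected result is no step beyond the scatter, with an estimated 1.3-fold higher number from compound 1 to compound 3 (0.12 log units; within the scatter). For compound 3 the estimated value in this assay is 4500 nM, with an expected range of 1500 nM to 13000 nM.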

Compound 3, half-maximal inhibitory concentration: 3010 nM
Compound 3: the middle estimate sits 1.5-fold (0.17 log units) above what was measured, within the range that was stated.
By their numbers in this assay, from the lowest: compounds 3 and 1 (each within the scatter of the next); then compound 2.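

In this assay furan-2-yl in place of phenyl on a double-bonded chain carbon bound to a double-bonded chain carbon gives a 1.1-fold lower number from compound 1 to compound 3 (0.06 log units; within the scatter) and so stays within the usual scatter. This first measured exchange at this position shows that a five-membered aromatic ring with one oxygen can stand for the six-membered carbon ring without a readable shift in the number. No measured evidence bears on why this is so. As far as these compounds go, whether a cyclohexyl ring, a carboxylic acid or an amine at this place would also stay within the scatter remains open.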